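Hydroxy additions on the hydrazone ring: notes toward compound 4

The source may report more compounds than this note shows. Statements on the series, on what has been measured and on what is new or still open speak of the compounds shown alone.

Compound 1 `O=C(N/N=C/c1ccccc1O)c1ccc2ccccc2n1` and compound 2 `O=C(N/N=C/c1cc(O)ccc1O)c1ccc2ccccc2n1` share one core; compound 3 `O=C(N/N=C/c1ccc(O)cc1O)c1ccnc2ccccc12` and the still unmeasured compound 4 `O=C(N/N=C/c1ccc(O)c(O)c1O)c1ccnc2ccccc12` share another. The difference between the two cores is not broken down here. In an ADME assay on U-937 cells (Homo sapiens) for cytotoxicity, read by MTT assay, with a stated time of 72 h (on this read-out higher numbers stand for lower toxicity in this test and lower numbers for higher toxicity in this test), compound 1 gives 56000 nM, compound 2 gives 159000 nM and compound 3 gives 34500 nM. Among the compounds with values here, the one measured step of this kind, a 2.8-fold higher number from compound 1 to compound 2 (0.45 log units; beyond the scatter), comes from hydroxy in place of hydrogen on an aromatic carbon.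

The change from compound 3 to compound 4 is the same kind of change, (hydroxy in place of hydrogen on an aromatic carbon). The place is not identical: in compound 4 the entering hydroxy sits ortho to two hydroxy groups and meta to a large group, whereas in compound 2 it sits meta to a large group and para to a hydroxy group. The only anchor for an expectation is the step in this assay from compound 1 to compound 2, so a step of about that size is expected, with a wide range because the cores and the surroundings of the new group differ. Compound 4 is expected to give 60000 nM in this assay, with a range from 20000 nM to 160000 nM. That corresponds to an expected step of a 1.7-fold higher number from compound 3 to compound 4 (0.24 log units; within the scatter).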

Compound 4, concentration lethal to 50% of the cells: 347000 nM
The estimate for compound 4 lay 5.8-fold (0.76 log units) below the measured number; measured number above the stated range.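

In this assay, hydroxy in place of hydrogen on an aromatic carbon gives a 10-fold higher number from compound 3 to compound 4 (1.00 log units; beyond the scatter) and so moves the number the same way on both cores, towards lower toxicity in this test. The direction carries from one core to the other, but the size does not: the same change on two cores in this assay, a 2.8-fold higher number (0.45 log units; beyond the scatter) from compound 1 to compound 2 and a 10-fold higher number (1.00 log units; beyond the scatter) from compound 3 to compound 4, 3.5-fold (0.55 log units) apart, beyond the scatter of two such steps. These notes rest on one pair per core, and the entering hydroxy stands in a different place in each pair (in compound 4 it is ortho to two hydroxy groups), so the gap cannot be assigned to the core or to the place, and no rule for further cores follows.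

As far as these compounds go, it remains open whether a hydroxy entering at the same place on both cores would give steps of one size. Also open, from the compounds shown here alone, is how a methoxy group or an amine on the aromatic carbon that carries the entering hydroxy in compound 4 would compare with that hydroxy in this assay.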